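This account rests on a few compounds, and the source may have more. Where it says the series, first, only, none or still open, it means among the compounds named here.

Measured so far in an assay on cells for inhibition of HSP60/HSP10 (Homo sapiens), with a stated time of 60 min; a higher number here means a weaker inhibitor, a lower number a stronger inhibitor: compound 1 `O=S(=O)(Nc1ccc(-c2nc3ccccc3o2)cc1)c1ccccc1O`; compound 2 `O=S(=O)(Nc1ccc(-c2nc3ccccc3o2)cc1)c1ccc(O)cc1`; compound 3 `COc1ccccc1S(=O)(=O)Nc1ccc(-c2nc3ccccc3o2)cc1`.

In this assay compound 1 gives only a limit of the assay, > 100000 nM. Compound 2 gives a numerical value, 78000 nM, in this assay. Compound 3 again reaches only a limit of the assay, > 100000 nM. Compound 3 therefore stands at the top of the numbers shown, and because of the limit of > 100000 nM in this assay, at which 2 of the 3 values shown sit, its value is not a number but a floor.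

The measured steps: an at least 1.2-fold lower number from compound 1 to compound 2 (0.10 log units; that floor lies within the scatter). an at least 1.2-fold higher number from compound 2 to compound 3 (0.10 log units; that floor lies within the scatter). a step that the two limits leave unreadable from compound 1 to compound 3, where a methyl replaces a hydrogen on the ring oxygen. All three steps start or end at a limit, and none adds a halogen.

Compound 4 `COc1ccc(Cl)cc1S(=O)(=O)Nc1ccc(-c2nc3ccccc3o2)cc1` differs from compound 3 by chloro in place of hydrogen on an aromatic carbon, that is, 2-methoxyphenyl becomes 5-chloro-2-methoxyphenyl. Among the measured compounds shown here, no measured step bears directly on this change; the nearest comparisons, from compound 1 to compound 3 and from compound 2 to compound 3, leave compound 3 at the limit, so compound 4 is expected to stay there too, with a number no higher from compound 3 to compound 4 (the limit leaves the size open) expected to be no step beyond the scatter. Compound 4 is estimated at 100000 nM, in the range 40000 nM to 300000 nM, most likely reported as a limit.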

Compound 4, half-maximal inhibitory concentration: > 100000 nM
Compound 4: only a limit was reported (the forecaster's own chance of this, stated with the estimate: 70%); the middle value sits exactly at the limit.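

The first halogen in the series, chloro on the aromatic carbon para to the methoxy group, does not bring this sulfonamide off the limit: in this assay compound 4 gives > 100000 nM as a limit of the assay and not a number. The steps from compound 3 and from compound 1 to compound 4 cannot be read because both ends of each step are limits: the limit of > 100000 nM in this assay, at which 3 of the 4 values shown sit. Among the compounds shown here, the only readable step is an at least 1.2-fold higher number from compound 2 to compound 4 (0.10 log units; that floor lies within the scatter) and this floor does not separate the 5-chloro-2-methoxyphenyl of compound 4 from the 4-hydroxyphenyl of compound 2.

Any effect of chloro on this ring therefore remains hidden behind the limit. In this assay, for the compounds shown here, compound 2 with 78000 nM remains the only compound here with a number. Still open, on these data alone, is whether chloro on the 4-hydroxyphenyl ring of compound 2, or an amine or a carboxylic acid at the position taken by chloro in compound 4, would give a number in this assay and how it would compare with compound 2.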